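The compounds below may be only part of what the source reports. "The series", "measured", "known", "first", "only" and "open" are said of these compounds alone.

Compound 1 `CCOC(COC(N)=O)C1=C(N2CC2)C(=O)C(C)=C(N2CC2)C1=O` is one of three compounds that have been measured in a functional assay on L1210 cells (Mus musculus), with a stated time of 12 days (a lower number here means a less potent compound, a higher number a more potent compound, by a factor of ten per unit of this negative logarithm), where compound 1 gives 6.18. That is the highest of the three numbers. Compound 2 `CCC1=C(N2CC2)C(=O)C(C(COC(N)=O)OC)=C(N2CC2)C1=O` gives 6.16 in this assay, which lies within the scatter of compound 1, so the two cannot be told apart. Compound 3 `COCCC1=C(N2CC2)C(=O)C(CCOC)=C(N2CC2)C1=O`, which carries no carbamate, gives 5.69 in this assay, a number beyond the scatter below compound 1. No pair among these three differs in a single place, so no measured step is available to guide the next change.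

Compound 4 `CC1=C(N2CC2)C(=O)C(C(C)COC(N)=O)=C(N2CC2)C1=O` has not yet been measured. It differs from compound 1 in one way: methyl in place of ethoxy on a saturated chain carbon bound to a double-bonded ring carbon and a saturated chain carbon. The carbamate that compounds 1 and 2 share is kept. Among the measured compounds shown here, since compound 3 is the only compound that is clearly weaker than compound 1 and it differs from compound 1 in more than one place, the effect of removing the ethoxy alone is not known. A small step downward is expected, but one that stays within the scatter. Compound 4 is estimated to give 5.9 in this assay, between 5.4 and 6.4, an expected step from compound 1 to compound 4 of a number 0.28 log units lower from compound 1 to compound 4 (within the scatter).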

Compound 4, logarithm of the reciprocal of the active concentration, log(1/C): 6.41
Beside the measured number, compound 4's estimate is 0.51 log units below it, outside the stated range (above it).
By their numbers in this assay, from the lowest: compound 3; then compounds 2, 1 and 4 (each within the scatter of the next).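

The first step measured at this place is a number 0.23 log units higher from compound 1 to compound 4 (within the scatter) in this assay, so the two compounds cannot be told apart. On this one pair, methyl in place of ethoxy on a saturated chain carbon bound to a double-bonded ring carbon and a saturated chain carbon removes the one hydrogen-bond acceptor of the ethoxy and two of its heavy atoms, with the carbamate kept, and the change stays inside the scatter. No measurement shown here accounts for this result, and the pair alone shows only that the two groups are not separated in this read-out.

Going by these compounds, whether a hydroxyl, an amine or a longer chain such as propyl on this carbon would also stay within the scatter of compound 1 in this assay remains open, as does what a plain hydrogen there would give. No pair shown differs in the carbamate alone, so what that group contributes to the number in this assay also remains unknown.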